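The source may hold more compounds than are shown below. What is called first, only, known or untested is meant among the compounds shown, and "the series" means these compounds.

Compound 1 `CC1CCN(c2c(S(=O)(=O)c3ccc(F)cc3)cnc3cc(Cl)ccc23)CC1`: 91%
Compound 2 `CC1CCN(c2c(S(=O)(=O)c3cc(Cl)cc(Cl)c3)cnc3cc(Cl)ccc23)CC1`: 93%
Compound 3 `Cc1ccc(S(=O)(=O)c2cnc3cc(Cl)ccc3c2N2CCC(C)CC2)cc1C`: 86%

In an assay on isolated protein for displacement of a labelled ligand from metabotropic glutamate receptor 5 (Homo sapiens), with a stated time of 60 min, tested at 1 uM (a higher number here means more inhibition at the concentration tested (going by the name of the read-out), a lower number less inhibition), compound 3 has the lowest of the three numbers, but the steps of a number 5 percentage points lower from compound 1 to compound 3 (within the scatter) and a number 7 percentage points lower from compound 2 to compound 3 (within the scatter) both lie within the usual scatter, so the three compounds cannot be told apart on these data. Compound 4 `Cc1ccc(S(=O)(=O)c2cnc3cc(Cl)ccc3c2N2CCC(C)CC2)cc1` differs from compound 3 by hydrogen in place of methyl on an aromatic carbon. Every measured step swaps the whole ring on the sulfonyl sulfur: a number 2 percentage points higher from compound 1 to compound 2 (within the scatter), a number 5 percentage points lower from compound 1 to compound 3 (within the scatter) and a number 7 percentage points lower from compound 2 to compound 3 (within the scatter), none of them beyond the scatter. Among the compounds with values here, no measured step removes a single methyl from that ring, so the change is judged only from those whole-ring swaps. For compound 4 the expected step is no change at the digits printed from compound 3 to compound 4 (within the scatter), not beyond the scatter. Compound 4 is therefore estimated at 86%, between 74% and 95%.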

Compound 4, a percentage reported as inhibition, at one concentration (the size of the read-out at that concentration, not a potency): 94%
Compound 4: the middle estimate sits 8 percentage points below what was measured; low and high end bracket the measured number.
By their numbers in this assay, from the lowest: compounds 3, 1, 2 and 4 (each within the scatter of the next).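

Taking one methyl off the 3,4-dimethylphenyl ring, the first change on this ring smaller than a whole-ring swap, gives a number 8 percentage points higher from compound 3 to compound 4 (within the scatter) in this assay and so does not separate the two compounds. The 4-methylphenyl ring also stays level with the other rings, as a number 1 percentage points higher from compound 2 to compound 4 (within the scatter) and a number 3 percentage points higher from compound 1 to compound 4 (within the scatter) both show. No measurement here bears on why these numbers fall as they do. Going by these compounds, whether an amine or a carboxylic acid on this ring would give a step beyond the scatter remains open. With one test concentration, any differences in potency among these compounds also remain open.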